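The compounds below may be only part of what the source reports. "The series", "measured", "known", "first", "only" and "open" are said of these compounds alone.

Measured so far in a functional assay on PC-3 cells (Homo sapiens) for cytotoxicity, read by MTT assay, with a stated time of 48 h; a higher number here means a weaker inhibitor, a lower number a stronger inhibitor:
- compound 1 `c1ccc(-c2nc(-c3c[nH]c4ccccc34)co2)cc1` gives 170000 nM
- compound 2 `Cc1nc(-c2c[nH]c3ccccc23)co1` gives 337000 nM
- compound 3 `COc1ccc(-c2nc(-c3c[nH]c4ccccc34)co2)cc1OC` gives 359000 nM

Compound 2 holds the second highest of the three numbers; compound 3 sits nearest to it and compound 1 furthest, both within the scatter. Compound 4 `Fc1ccc(-c2nc(-c3c[nH]c4ccccc34)co2)cc1` is not yet measured. It differs from compound 2 by 4-fluorophenyl in place of methyl on an aromatic carbon. Going by the values given here, the one measured step that bears on this change is a 2.0-fold higher number from compound 1 to compound 2 (0.30 log units; within the scatter), and the step from compound 2 to compound 4 runs the other way: a 4-fluorophenyl enters where compound 1 carries a plain phenyl. Compound 3 carries a substituted phenyl at the same position and gives a number close to compound 2, so the expected move is small. For compound 4 the number is expected to be lower than for compound 2 by about a 1.9-fold lower number from compound 2 to compound 4 (0.27 log units; within the scatter), an estimate of 180000 nM with a range from 90000 nM to 400000 nM.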

Compound 4, half-maximal inhibitory concentration: 42800 nM
Estimate against measurement, compound 4: 4.2-fold (0.62 log units) above, and the stated range ends above it.
By their numbers in this assay, from the lowest: compound 4; then compounds 1, 2 and 3 (each within the scatter of the next, the first and the last beyond it).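

In this assay, this position now shows a change beyond the scatter: a 7.9-fold lower number from compound 2 to compound 4 (0.90 log units; beyond the scatter), whereas the earlier exchange of methyl and phenyl stayed within it. Fluoro in place of hydrogen on the phenyl ring gives a 4.0-fold lower number from compound 1 to compound 4 (0.60 log units; beyond the scatter), so this single-atom change moves the number here by itself. Nothing measured on hand bears on why these steps occur.
Open, as far as these compounds go, is whether chloro or an amine in place of the fluoro gives a step of similar size. Also open, from the compounds shown here alone, is whether fluoro elsewhere on the phenyl ring does the same.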